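This account rests on a few compounds, and the source may have more. Where it says the series, first, only, none or still open, it means among the compounds named here.

Measured compounds in the series:

- compound 1, `Cc1c(OCCCCOc2ccc(C(=O)O)cc2Cl)ccc(C(=O)CC2CCCC2)c1O`: > 10000 nM
- compound 2, `Cc1c(OCCCCOc2ccccc2C(=O)O)ccc(C(=O)CC(C)C)c1O`: "not determined" (no result reported)
- compound 3, `CCCC(=O)c1ccc(OCCCCOc2cc(C(=O)O)ccc2OC)c(C)c1O`: 496 nM

In an assay on HEK293 cells for positive allosteric modulation of metabotropic glutamate receptor 3 (Rattus norvegicus), read by thallium flux, with a stated time of 2.5 min (on this read-out lower numbers stand for an effect already at smaller amounts and higher numbers for an effect only at larger amounts of compound), compound 1 reaches only the upper limit of the assay, > 10000 nM, so no number is known for it; the entry is a limit and not a value (the limit of > 10000 nM in this assay, at which 1 of the 3 values shown sits). For compound 2 the assay returned no result, "not determined" (no result reported). Going by the values given here, compound 3 is the only member with a measured number, 496 nM. Among the compounds with values here, compound 1 therefore stands at the limit of this assay, with one further entry that carries no number beside it, and no step between two measured compounds can be drawn from these three.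

The next compound, compound 4, `Cc1c(OCCCCOCOc2ccc(C(=O)O)cc2)ccc(C(=O)CC2CCCC2)c1O`, is not yet measured in this assay. It differs from compound 1 in one place: (4-carboxyphenoxy)methyl in place of 4-carboxy-2-chlorophenyl on an oxygen on a saturated carbon. The leaving group carries a chlorine on the aromatic ring; the entering group extends the linker by a methylene bound through oxygen to the carboxyphenyl ring.

Within the data shown here, with no measured step between related compounds, the size of the change from compound 1 to compound 4 in this assay is open. The expectation for compound 4 is a step of an at least 1.2-fold lower number from compound 1 to compound 4 (0.09 log units; that floor lies within the scatter), toward smaller amounts but close to the scatter, since compound 1 sits only at a limit and gives no anchor. Compound 4 is estimated at 8000 nM, expected to fall between 2000 nM and 30000 nM.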

Compound 4, half-maximal effective concentration: 1910 nM
Compound 4: the middle estimate sits 4.2-fold (0.62 log units) above what was measured, outside the stated range (below it).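

Placing (4-carboxyphenoxy)methyl in place of 4-carboxy-2-chlorophenyl on an oxygen on a saturated carbon gives, in this assay, an at least 5.2-fold lower number from compound 1 to compound 4 (0.71 log units; beyond the scatter), the first readable step in the series and one that lies beyond the scatter. With the rest of the structure shared, this one place separates a compound with a measured number from a compound with only an assay limit, so the read-out responds to a change here. The true size of the step remains unknown, and only its floor can be stated, because compound 1 stands at a limit: the limit of > 10000 nM in this assay, at which 1 of the 4 values shown sits.

The change removes the chlorine and extends the linker through a methylene bound to oxygen in a single move, so the compounds shown do not separate the contribution of either part. On these data alone, whether an unchlorinated aryl group on the original linker, a longer chain at this place or an amide in place of the carboxylic acid would move the number further, and in which direction, remains open.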